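The source may report more compounds than this note shows. Statements on the series, on what has been measured and on what is new or still open speak of the compounds shown alone.

Compound 1 `O=C(CCC1=CCN(CCCc2ccc(Cl)cc2)C1=O)NO`: 2210 nM
Compound 2 `O=C(CCC1=CCN(Cc2ccc(Br)cc2F)C1=O)NO`: 1990 nM

Of the compounds shown here, two have so far been measured in a functional assay on MDA-MB-231 cells (Homo sapiens) for inhibition, read by sulforhodamine B assay; a lower number here means a stronger inhibitor of growth, a higher number a weaker inhibitor of growth. Compound 1 gives 2210 nM, the higher of the two numbers, and compound 2 gives 1990 nM; the two values lie within the scatter of each other, so no order between them can be claimed. Within the data shown here, no step between measured compounds that differ in one place is available, and the two measured compounds differ from each other in more than one place. Compound 3 `Cc1ccc(CCCN2CC=C(CCC(=O)NO)C2=O)cc1` keeps the shared core of compound 1 and differs from it in one place: methyl in place of chloro on an aromatic carbon. Among the measured compounds shown here, with no measured step to inform this change, the step of a 1.1-fold higher number from compound 1 to compound 3 (0.05 log units; within the scatter) is expected to stay within the scatter, with no clear direction. Compound 3 is accordingly expected to give about 2500 nM in this assay, with a likely range from 1000 nM to 6000 nM.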

Compound 3, concentration for 50% growth inhibition: 2210 nM
Compound 3: the middle estimate sits 1.1-fold (0.05 log units) above what was measured, within the range that was stated.
By their numbers in this assay, from the lowest: compounds 2, 1 and 3 (each within the scatter of the next).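

In this assay, among these compounds, putting methyl in place of chloro on the aromatic carbon gives no change at the digits printed from compound 1 to compound 3 (within the scatter), the first step here that can be read between compounds differing in one place. On the core of compound 1, this read-out therefore does not separate 4-chlorophenyl from 4-methylphenyl, although this single pair says nothing about other groups at this position. No accompanying measurement bears on this result.

The compounds shown leave open whether a group of another kind at this position, such as an amine or a carboxylic acid, would shift the number beyond the scatter. They also leave open whether a longer chain in place of the one carrying the aromatic ring would change the number.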